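Bromo in place of hydrogen on compound 3: cytotoxicity outlook

This account rests on a few compounds, and the source may have more. Where it says the series, first, only, none or still open, it means among the compounds named here.

Compound 3 `O=c1ccc2ccccc2n1Cc1nc2ccccc2n1CCCCF` gives 103000 nM in an ADME assay on HEp-2 cells (Homo sapiens) for cytotoxicity (on this read-out lower numbers stand for higher toxicity in this test and higher numbers for lower toxicity in this test), the highest of the three numbers, though its gap to compound 1 `CC(C)CCn1c(CN2C(=O)N(CC(=O)O)S(=O)(=O)c3ccccc32)nc2ccccc21` at 60200 nM and to compound 2 `COc1cc(=O)n(Cc2nc3ccccc3n2CCCCF)c2ccccc12` at 59500 nM lies within the scatter. Among the compounds with values here, the one single-point step, a 1.7-fold higher number from compound 2 to compound 3 (0.24 log units; within the scatter), also stays within the scatter. Compound 4 `O=c1c(Br)cc2ccccc2n1Cc1nc2ccccc2n1CCCCF` differs from compound 3 by bromo in place of hydrogen on an aromatic carbon. Within the data shown here, no measured step involves a bromo group; the only change on this ring, hydrogen for methoxy, moved nothing beyond the scatter, so the expected step of a 1.3-fold lower number from compound 3 to compound 4 (0.11 log units; within the scatter) is likewise none beyond the scatter. Compound 4 is therefore estimated at 80000 nM in this assay, with a range of 30000 nM to 200000 nM.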

Compound 4, half-maximal cytotoxic concentration: 26200 nM
The estimate for compound 4 lay 3.1-fold (0.48 log units) above the measured number; the measured number lies below the stated range.
By their numbers in this assay, from the lowest: compound 4; then compounds 2, 1 and 3 (each within the scatter of the next).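

In this assay, within the data shown here, bromo in place of hydrogen, two atoms from the ring nitrogen, gives a 3.9-fold lower number from compound 3 to compound 4 (0.59 log units; beyond the scatter) and is the first step to pass the scatter, though only modestly. Among these compounds, this carbon therefore responds to substitution, whereas the one earlier step on this ring, involving methoxy, stayed within the scatter. No measurement bearing on the reason for this step is available. From the compounds shown here alone, whether the lower number belongs to bromo itself or to any substituent on this carbon remains open; chloro, methyl or an amine here would separate the two. Whether the step carries over to other side chains on the shared core is also unresolved.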